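A Methyl Added to the Benzyl Oxime Ether

The source may report more compounds than this note shows. Statements on the series, on what has been measured and on what is new or still open speak of the compounds shown alone.

Going by the values given here, compound 1 `c1ccc(CO/N=C2/C(c3c[nH]c4ccccc34)=Nc3ccccc32)cc1` and compound 2 `N#Cc1ccc2c(c1)/C(=N\OCc1ccccc1)C(c1c[nH]c3ccc(C#N)cc13)=N2` are the two measured members of this set. In a functional assay on T-24 cells (Homo sapiens) for cytotoxicity, read by MTT assay, with a stated time of 2 days (a lower number here means a stronger inhibitor, a higher number a weaker inhibitor), compound 1 gives 12200 nM, and compound 2 gives 18600 nM. Compound 1 carries the smaller of the two numbers shown, yet the gap to compound 2 falls within the usual scatter, so the two cannot be told apart on these data. Compound 3 `Cc1ccc(CO/N=C2/C(c3c[nH]c4ccccc34)=Nc3ccccc32)cc1` arises from compound 1 by methyl in place of hydrogen on an aromatic carbon, turning benzyl into 4-methylbenzyl. Among the compounds with values here, no measured pair in this set shows what such a change does, so the only guide is the number of compound 1 itself. A step within the scatter is expected, in no particular direction. Compound 3 is therefore estimated at 11000 nM, with a range from 4500 nM to 28000 nM, which means an expected step of a 1.1-fold lower number from compound 1 to compound 3 (0.04 log units; within the scatter).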

Compound 3, half-maximal inhibitory concentration: 23500 nM
Compound 3: middle estimate off by 2.1-fold (0.33 log units), on the low side; measured number inside the range.
By their numbers in this assay, from the lowest: compounds 1, 2 and 3 (each within the scatter of the next).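

The benzyl group of compound 1 now has its first measured change: in this assay, going to 4-methylbenzyl gives a 1.9-fold higher number from compound 1 to compound 3 (0.28 log units; within the scatter), so on these data compound 1 and compound 3 cannot be told apart. A single methyl on this aromatic carbon, para to a large group, therefore leaves the cell reading inside the usual scatter, which the two earlier compounds could not show because they differ from each other elsewhere. No measurement here offers an explanation for the size of this step.

On these data alone, it remains open whether an amine, a carboxylic acid or a longer chain such as butyl on this same carbon would move the number beyond the scatter. Whether methyl behaves the same way on compound 2 is also unknown.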